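Acetoxymethyl in place of ethoxy on the core of compound 1

This account rests on a few compounds, and the source may have more. Where it says the series, first, only, none or still open, it means among the compounds named here.

Three compounds have been measured in a functional assay for inhibition of Vanilloid receptor (Rattus norvegicus); a higher number here means a weaker inhibitor, a lower number a stronger inhibitor:
compound 1 `CCOc1cc(C(C)(C)C)ccc1C/N=C(\S)NCc1ccc(NS(C)(=O)=O)cc1` gives 1100 nM;
compound 2 `CCCCOc1cc(C(C)(C)C)ccc1C/N=C(\S)NCc1ccc(NS(C)(=O)=O)cc1` gives 60 nM;
compound 3 `COCCOc1cc(C(C)(C)C)ccc1C/N=C(\S)NCc1ccc(NS(C)(=O)=O)cc1` gives 60 nM.

Compound 1 stands highest of these three numbers. The steps of an 18-fold lower number from compound 1 to compound 2 (1.26 log units; beyond the scatter) and an 18-fold lower number from compound 1 to compound 3 (1.26 log units; beyond the scatter) were both large, and between the two larger compounds there was no change at the digits printed from compound 2 to compound 3 (within the scatter). Compound 4 `CC(=O)OCc1cc(C(C)(C)C)ccc1C/N=C(\S)NCc1ccc(NS(C)(=O)=O)cc1` differs from compound 1 by acetoxymethyl in place of ethoxy on an aromatic carbon. For the measured compounds named here, both measured steps bear on it only loosely: they enlarged the chain, whereas here the ethoxy is replaced outright, and no measured step covers such a change. A downward step is expected, though smaller than the two already in hand, and the estimated step is a 4.4-fold lower number from compound 1 to compound 4 (0.64 log units; beyond the scatter). Compound 4 is therefore estimated at 250 nM, within 60 nM to 1000 nM.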

Compound 4, half-maximal inhibitory concentration: 580 nM
Compound 4: the middle estimate sits 2.3-fold (0.37 log units) below what was measured, and the stated range covers the measured number.
By their numbers in this assay, from the lowest: compounds 2 and 3 (each within the scatter of the next); then compounds 4 and 1 (each within the scatter of the next).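

Replacing ethoxy outright with acetoxymethyl on this aromatic carbon gave no change beyond the scatter, with a 1.9-fold lower number from compound 1 to compound 4 (0.28 log units; within the scatter). Butoxy and 2-methoxyethoxy both stand clearly apart from acetoxymethyl, with a 9.7-fold higher number from compound 2 to compound 4 (0.99 log units; beyond the scatter) and a 9.7-fold higher number from compound 3 to compound 4 (0.99 log units; beyond the scatter), so at this position a larger group does not by itself match those two chains. No measurement at hand accounts for this difference.

From the compounds shown here alone, it remains open whether propoxy would fall with ethoxy or with butoxy. Going by these compounds, the effect of a 2-aminoethoxy chain or a longer pentyloxy chain at this position also remains open.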